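A few compounds are considered here, and "the series" means these few. Any claim that something is new, unique, unknown or untested is made for them only; others in the source may bear on it.

Working notes on the series.

Compound 1 `CC(C)(C)c1ccc(Cn2cc(C(N)=O)c3c(N)ncnc32)cc1` gives 900 nM in a functional assay on KB cells (Homo sapiens) for cytotoxicity; on this read-out higher numbers stand for weaker inhibition and lower numbers for stronger inhibition. Compound 2 `CC(C)(C)c1ccc(Cn2cc(C#N)c3c(N)ncnc32)cc1` gives 3000 nM, and compound 3 `CC(C)(C)c1ccc(Cn2cc(C(=N)S)c3c(N)ncnc32)cc1` gives 7000 nM. On these numbers compound 2 stands second highest of three: the nearest is compound 3, a step of a 2.3-fold higher number from compound 2 to compound 3 (0.37 log units; beyond the scatter), the furthest is compound 1, reached by a 3.3-fold higher number from compound 1 to compound 2 (0.52 log units; beyond the scatter) in the other direction.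

Compound 4 `N#Cc1cn(Cc2ccccc2)c2ncnc(N)c12` is not yet measured. Its change from compound 2 is hydrogen in place of tert-butyl on an aromatic carbon; the hydrogen sits on an aromatic carbon of a six-membered aromatic ring of carbon only, para to a large group. Among the compounds with values here, none of the measured steps bears on this position: a 3.3-fold higher number from compound 1 to compound 2 (0.52 log units; beyond the scatter), a 7.8-fold higher number from compound 1 to compound 3 (0.89 log units; beyond the scatter) and a 2.3-fold higher number from compound 2 to compound 3 (0.37 log units; beyond the scatter) all concern the group on the aromatic carbon of the shared core, not the tert-butyl. The direction is therefore unsupported by data, and a wide range is needed. Compound 4 is estimated at 6000 nM, with a range from 1500 nM to 25000 nM. This estimate means an expected step of a 2.0-fold higher number from compound 2 to compound 4 (0.30 log units; within the scatter).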

Compound 4, half-maximal inhibitory concentration: > 100000 nM
Compound 4: a limit, no number; the forecaster's own chance of this, stated with the estimate: 15%; middle value at least 16-fold (1.22 log units) away from the limit.
By their numbers in this assay, from the lowest: compound 1; then compound 2; then compound 3. At a limit, above all of these: compound 4.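

The earlier compounds shown here all carry tert-butyl and vary only the group on the aromatic carbon of the shared core, with modest steps. Hydrogen in place of tert-butyl, on the aromatic carbon para to a large group, gives an at least 33-fold higher number from compound 2 to compound 4 (1.52 log units; beyond the scatter) and so makes this position the most sensitive change in the series so far, with a large step against those modest ones. For compound 4 the read-out in this assay is a limit and not a number, so the step gives only a lower bound on the true size of the change: the limit of > 100000 nM in this assay, at which 1 of the 4 values shown sits.

The compounds shown leave open what a methyl, an isopropyl group, a chlorine atom or an amine would give at this place. They also leave open whether the same exchange on compound 1, with its carbamoyl group, would give a step of similar size.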